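Cyclohexyl for 4-Methylbenzyl on a Non-Cytotoxic Amide

The source may hold more compounds than are shown below. What is called first, only, known or untested is meant among the compounds shown, and "the series" means these compounds.

Measured compounds:
compound 1 `C=CC1=C(C(=O)NCc2ccc(C)cc2)C(c2ccc(F)cc2)OC1` — > 100000 nM
compound 2 `C=CC1=C(C(=O)Nc2ccccc2)C(c2ccc(Cl)c(Cl)c2)OC1` — > 100000 nM

In a functional assay on HeLa cells (Homo sapiens) for cytotoxicity, read by MTT assay, with a stated time of 24 h (a lower number here means a stronger inhibitor, a higher number a weaker inhibitor), compound 1 gives > 100000 nM, which is a limit of the assay and not a number. In this assay compound 2 gives > 100000 nM, also a limit. Compound 1 therefore stands at the limit of > 100000 nM in this assay, at which 2 of the 2 values shown sit, so the numbers shown say only that neither compound reaches measurable cytotoxicity there.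

Compound 3 `C=CC1=C(C(=O)NC2CCCCC2)C(c2ccc(F)cc2)OC1` differs from compound 1 in a single place: cyclohexyl in place of 4-methylbenzyl on an amide-type nitrogen. For the measured compounds named here, no step between two measured compounds is available to guide the size of this change, and the two values shown differ in more than one place and are both limits.

With compound 1 at a limit, the step of a number no higher from compound 1 to compound 3 (the limit leaves the size open) is expected to show nothing beyond the scatter, most likely another limit. Compound 3 is thus estimated at 100000 nM, with a range from 30000 nM to 300000 nM.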

Compound 3, half-maximal inhibitory concentration: > 100000 nM
Compound 3: a limit, no number (the forecaster's own chance of this, stated with the estimate: 85%); the middle value lies on the limit itself.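

Compound 3 gives > 100000 nM, a limit of the assay and not a number. For the compounds shown here, compound 1 also stands at a limit, and no step between compound 1 and compound 3 can be read. The compounds shown leave open whether any amide substituent on the shared core gives measurable cytotoxicity.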